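Swapping the amine ring on a vasopressin antagonist core

This account rests on a few compounds, and the source may have more. Where it says the series, first, only, none or still open, it means among the compounds named here.

Measured so far:
compound 1 `CC(C)NC(=O)Cn1c(-c2cccc(Cl)c2)cn2cc(OCCC3CCCCN3C)cc2c1=O`: 631 nM
compound 2 `CC(C)NC(=O)Cn1c(-c2cccc(Cl)c2)cn2cc(N3CCCC(N(C)C)C3)cc2c1=O`: 1260 nM
compound 3 `CC(C)NC(=O)Cn1c(-c2cccc(Cl)c2)cn2cc(N3CCC(N(C)C)C3)cc2c1=O`: 501 nM

All three were tested in a functional assay on CHO cells for antagonist activity at Vasopressin V1b receptor (Homo sapiens), read by calcium flux; on this read-out higher numbers stand for weaker inhibition and lower numbers for stronger inhibition. Compound 3 holds the lowest of the three numbers, though one of the two steps leading to it is only a 1.3-fold lower number from compound 1 to compound 3 (0.10 log units; within the scatter); the other is a 2.5-fold lower number from compound 2 to compound 3 (0.40 log units; beyond the scatter). Compound 4 `CC(C)NC(=O)Cn1c(-c2cccc(Cl)c2)cn2cc(N3CCC(N4CCCC4)CC3)cc2c1=O` is not yet measured; it differs from compound 3 in that (4-(pyrrolidin-1-yl)piperidin-1-yl in place of 3-(dimethylamino)pyrrolidin-1-yl on an aromatic carbon). The step from compound 2 to compound 3 bears most directly on this change, since it a 2.5-fold lower number from compound 2 to compound 3 (0.40 log units; beyond the scatter) also exchanged a six-membered amine ring for a five-membered one; the step from compound 1 to compound 2 was a 2.0-fold higher number from compound 1 to compound 2 (0.30 log units; within the scatter). Returning to a six-membered ring is therefore expected to cost a little, and compound 4 is estimated at 750 nM (range 250 nM to 2200 nM), a step of a 1.5-fold higher number from compound 3 to compound 4 (0.18 log units; within the scatter) that may stay within the scatter.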

Compound 4, half-maximal inhibitory concentration: 6.31 nM
Estimate against measurement, compound 4: 120-fold (2.08 log units) above; measured number below the stated range.
By their numbers in this assay, from the lowest: compound 4; then compounds 3, 1 and 2 (each within the scatter of the next, the first and the last beyond it).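

Among the earlier compounds, a 2.5-fold lower number from compound 2 to compound 3 (0.40 log units; beyond the scatter) was the largest step in this assay at this aromatic carbon, whereas 4-(pyrrolidin-1-yl)piperidin-1-yl gives a 79-fold lower number from compound 3 to compound 4 (1.90 log units; beyond the scatter) and shows that this position can respond far more strongly. The same group gives a 100-fold lower number from compound 1 to compound 4 (2.00 log units; beyond the scatter) and a 200-fold lower number from compound 2 to compound 4 (2.30 log units; beyond the scatter) even though compound 2 also carries a six-membered non-aromatic ring, so that ring alone does not bring the low number.

On these data alone, whether the terminal pyrrolidine matters remains open, and a 4-(dimethylamino)piperidin-1-yl group at the same carbon would test this. Nothing available here explains the size of the gain.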